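Amide-type nitrogen group: from compound 3 to compound 4

The compounds below may be only part of what the source reports. "The series", "measured", "known", "first", "only" and "open" are said of these compounds alone.

Measured in a functional assay on HeLa cells (Homo sapiens) for antiproliferative activity, read by MTT assay, with a stated time of 72 h; on this read-out higher numbers stand for weaker inhibition and lower numbers for stronger inhibition:
- Compound 1 `COc1cccc(N2C(=O)COc3ccc(-c4cnc(OC)c(NS(=O)(=O)c5ccc(F)cc5)c4)cc32)c1`: > 40000 nM, a limit of the assay.
- Compound 2 `COc1ncc(-c2ccc3c(c2)N(C2CC2)C(=O)CO3)cc1NS(=O)(=O)c1ccc(F)cc1`: 6030 nM.
- Compound 3 `COc1ncc(-c2ccc3c(c2)N(c2ccc(Cl)cc2)C(=O)CO3)cc1NS(=O)(=O)c1ccc(F)cc1`: 4830 nM.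

Compound 3 stands level with compound 2, as a 1.2-fold lower number from compound 2 to compound 3 (0.10 log units; within the scatter) shows. Compound 4 `COc1ncc(-c2ccc3c(c2)N(C(C)C)C(=O)CO3)cc1NS(=O)(=O)c1ccc(F)cc1` has isopropyl in place of 4-chlorophenyl on an amide-type nitrogen in a ring. Among the measured compounds shown here, the closest precedent is the change at the same nitrogen between cyclopropyl and 4-chlorophenyl, a 1.2-fold lower number from compound 2 to compound 3 (0.10 log units; within the scatter). The larger steps, an at least 6.6-fold lower number from compound 1 to compound 2 (0.82 log units; beyond the scatter) and an at least 8.2-fold lower number from compound 1 to compound 3 (0.91 log units; beyond the scatter), both leave the 3-methoxyphenyl of compound 1, a group absent from compound 3 and compound 4, so they bear less directly. The expected step is a 1.2-fold higher number from compound 3 to compound 4 (0.09 log units; within the scatter), none beyond the scatter. For compound 4 the estimate is 6000 nM, with an expected range of 2500 nM to 15000 nM.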

Compound 4, half-maximal inhibitory concentration: 2790 nM
The estimate for compound 4 lay 2.2-fold (0.33 log units) above the measured number; measured number inside the range.
By their numbers in this assay, from the lowest: compounds 4, 3 and 2 (each within the scatter of the next, the first and the last beyond it). At a limit, above all of these: compound 1.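

Isopropyl on the amide-type nitrogen, with a 1.7-fold lower number from compound 3 to compound 4 (0.24 log units; within the scatter), cannot be told apart from 4-chlorophenyl, so a number of this size does not require an aromatic ring at this position. Isopropyl in place of cyclopropyl gives a modest change, a 2.2-fold lower number from compound 2 to compound 4 (0.33 log units; beyond the scatter), the first beyond the scatter among the groups that leave compound 1 aside. The widest step, an at least 14-fold lower number from compound 1 to compound 4 (1.15 log units; beyond the scatter), starts from compound 1, whose value is a limit and not a number: the limit of > 40000 nM in this assay, at which 1 of the 4 values shown sits.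

Going by these compounds, whether an amine, a carboxylic acid or a longer chain on this nitrogen would move the number further remains open.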